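A few compounds are considered here, and "the series" means these few. Any claim that something is new, unique, unknown or untested is made for them only; others in the source may bear on it.

Working notes on the series in a functional assay on Mahlavu cells (Homo sapiens) for antiproliferative activity, read by sulforhodamine B assay, with a stated time of 72 h; on this read-out higher numbers stand for weaker inhibition and lower numbers for stronger inhibition.

Three compounds share one core and differ around the aryloxy arm. Compound 1 `Cc1ccccc1COc1ccc(-c2cc(CN3CCN(Cc4ccc(C(F)(F)F)cc4)CC3)no2)cc1` gives 6800 nM in this assay. Compound 2 `Fc1ccccc1COc1ccc(-c2cc(CN3CCN(Cc4ccc(C(F)(F)F)cc4)CC3)no2)cc1` gives 3100 nM in this assay. Compound 3 `Cc1cc(OCc2cccc(C#N)c2)ccc1-c1cc(CN2CCN(Cc3ccc(C(F)(F)F)cc3)CC2)no1` gives 500 nM in this assay, the lowest of the three numbers, with its steps to compound 2 and to compound 1 both beyond the scatter.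

Among the measured compounds shown here, the one counted step, a 2.2-fold lower number from compound 1 to compound 2 (0.34 log units; beyond the scatter), belongs to the change (fluoro in place of methyl on an aromatic carbon). The difference between the core of compound 1 and the core of compound 3 is not broken down here.

Compound 4 `N#Cc1cccc(COc2ccc(-c3cc(CN4CCN(Cc5ccc(C(F)(F)F)cc5)CC4)no3)c(F)c2)c1` is not yet measured in this assay. It differs from compound 3 by fluoro in place of methyl on an aromatic carbon. This is the same kind of change as that from compound 1 to compound 2, not the same: the place differs in that it is also meta to a (3-cyanobenzyl)oxy group, which compound 1 and compound 2 do not carry.

Expectation for compound 4: the single earlier occurrence of this kind of change gave a 2.2-fold lower number from compound 1 to compound 2 (0.34 log units; beyond the scatter), and a step of similar size, a 1.8-fold lower number from compound 3 to compound 4 (0.25 log units; within the scatter), is expected here, resting on that one pair only. On that basis compound 4 is estimated at 280 nM, with a plausible range from 120 nM to 700 nM, because the starting point is compound 3 at 500 nM.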

Compound 4, half-maximal inhibitory concentration: 400 nM
Estimate against measurement, compound 4: 1.4-fold (0.15 log units) below; the range from low to high includes it.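

In this assay the new step, a 1.3-fold lower number from compound 3 to compound 4 (0.10 log units; within the scatter), stays within the scatter, whereas the earlier step on the other core lies beyond it, yet the two steps cannot be told apart: the same change on two cores in this assay, a 2.2-fold lower number (0.34 log units; beyond the scatter) from compound 1 to compound 2 and a 1.3-fold lower number (0.10 log units; within the scatter) from compound 3 to compound 4, 1.8-fold (0.24 log units) apart, within the scatter of two such steps. Fluoro in place of methyl on an aromatic carbon therefore carries from the core of compound 1 to the core of compound 3 with no measurable difference in step size, and the result gives no sign that the second core changes the outcome of this exchange. This rests on two pairs in a single assay, with the exchange at a different place in each pair, the second being meta to a (3-cyanobenzyl)oxy group, so it neither fixes a general size for the step nor explains it.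

Still open, from the compounds shown here alone, is how other groups at this place would read in this assay, for example chloro, methoxy or a plain hydrogen in place of the methyl of compound 3. Also open, going by these compounds, is what the nitrile itself contributes, which a pair differing only in that group, with hydrogen or an amide in its place, would be needed to separate.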